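Chloro for fluoro on the aryl of compound 2

This account rests on a few compounds, and the source may have more. Where it says the series, first, only, none or still open, it means among the compounds named here.

Measured so far:
compound 1 `Clc1ccc(C2=NN(c3ccccc3)C(c3cn(-c4ccccc4)nc3-c3ccc(Cl)c(Cl)c3)C2)cc1`: 61.7%
compound 2 `O=[N+]([O-])c1ccc(N2N=C(c3ccc(F)cc3)CC2c2cn(-c3ccccc3)nc2-c2ccc(Cl)c(Cl)c2)cc1`: 65.6%

In a functional assay on the whole organism (strain Wistar) for inhibition, with Rattus norvegicus as the target, read by paw edema, with stated times of 30 min and 120 min, at a dose of 50 mg/kg by the oral route (on this read-out higher numbers stand for more inhibition at the one dose given (going by the name of the read-out) and lower numbers for less inhibition), compound 1 gives 61.7% and compound 2 gives 65.6%; the two numbers lie within the scatter of each other, so compound 2 sits level with compound 1 on what has been measured. Compound 3 `O=[N+]([O-])c1ccc(N2N=C(c3ccc(Cl)cc3)CC2c2cn(-c3ccccc3)nc2-c2ccc(Cl)c(Cl)c2)cc1` differs from compound 2 in one place: chloro in place of fluoro on an aromatic carbon. Within the data shown here, no measured pair carries this change, so nothing in the data fixes its size. With compound 2 at 65.6%, the expected step is a number 1.6 percentage points lower from compound 2 to compound 3 (within the scatter), none beyond the scatter. Compound 3 is therefore estimated at 64%, within a range from 52% to 76%.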

Compound 3, a percentage reported as inhibition, in the whole organism at one dose (the size of the read-out at that dose, not a potency): 69.5%
Estimate against measurement, compound 3: 5.5 percentage points below; the measured number falls inside the stated range.
By their numbers in this assay, from the lowest: compounds 1, 2 and 3 (each within the scatter of the next).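

In this assay chloro in place of fluoro gives a number 3.9 percentage points higher from compound 2 to compound 3 (within the scatter) and so separates the two halogens at this aromatic carbon by no readable margin. Nitro in place of hydrogen on an aromatic carbon gives a number 7.8 percentage points higher from compound 1 to compound 3 (within the scatter) and is likewise not separable from the scatter. Nothing at hand accounts for either step.

On these data alone, whether bromo or methoxy at the same aromatic carbon would stay level with chloro remains open. So does the effect of an amine or a carboxylic acid in place of the nitro of compound 3.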